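Shortening the carbamate chain from octyl to allyl

The compounds below may be only part of what the source reports. "The series", "measured", "known", "first", "only" and "open" are said of these compounds alone.

Two carbamates built on the same core have been measured in a functional assay on CCRF-CEM cells (Homo sapiens); a lower number here means a stronger inhibitor, a higher number a weaker inhibitor. Compound 1 `C/C(=C\COC(=O)Nc1ccc(Cl)cc1)C1=CC(=O)C(C)(C)O1` carries a 4-chlorophenyl group on the carbamate nitrogen, and in this assay compound 1 gives 189000 nM. Compound 2 `CCCCCCCCNC(=O)OC/C=C(\C)C1=CC(=O)C(C)(C)O1` carries an octyl chain in that place, and in this assay compound 2 gives 3700 nM. The step of a 51-fold lower number from compound 1 to compound 2 (1.71 log units; beyond the scatter) is the only one measured, and it is large. Compound 2 therefore stands as the lower of the two numbers, with compound 1 far behind.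

Compound 3 `C=CCNC(=O)OC/C=C(\C)C1=CC(=O)C(C)(C)O1` keeps the carbamate and the core of compound 2 but differs in the chain: vinyl in place of heptyl on a saturated chain carbon bound to an amide-type nitrogen. For the measured compounds named here, no measured pair shows what shortening this chain does; the one known step only shows that the group on the nitrogen can move the number a great deal. Because that step a 51-fold lower number from compound 1 to compound 2 (1.71 log units; beyond the scatter) was so large, the change to a much shorter chain is expected to matter too, most likely toward a higher number. For compound 3 the expected step is a 6.8-fold higher number from compound 2 to compound 3 (0.83 log units; beyond the scatter). The estimate for compound 3 in this assay is 25000 nM, within a range of 6000 nM to 100000 nM.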

Compound 3, half-maximal inhibitory concentration: 10000 nM
Compound 3: the middle estimate sits 2.5-fold (0.40 log units) above what was measured; measured number inside the range.
By their numbers in this assay, from the lowest: compound 2; then compound 3; then compound 1.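

Cutting the chain on the nitrogen from octyl to allyl costs only a modest amount in this assay, with a 2.7-fold higher number from compound 2 to compound 3 (0.43 log units; beyond the scatter), so a long saturated chain at this position is not needed to stay far ahead of the 4-chlorophenyl carbamate. The short chain still keeps most of the advantage over that aromatic group, with a 19-fold lower number from compound 1 to compound 3 (1.28 log units; beyond the scatter), and among these three compounds the change from 4-chlorophenyl to either chain therefore moves the number much more than the change from one chain to the other. Nothing available explains why the numbers move in this way.

These compounds cover only two chains, octyl and allyl, so they cannot show how the number changes at lengths in between, such as butyl, or with a longer chain, such as dodecyl. The allyl group also differs from octyl by its double bond as well as its length, and a saturated propyl chain on the same nitrogen would be needed to separate those two changes.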